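Replacing the lactam amide with a methylated pyrrolidine amide

The compounds below may be only part of what the source reports. "The series", "measured", "known", "first", "only" and "open" are said of these compounds alone.

Compound 3 `CN1CCC(NC(=O)c2ccncc2Nc2cc(-c3ccc4ccn(C)c4c3)c3nccnc3c2)CC1=O` holds the highest of the three numbers in a physicochemical assay for solubility, read by spectrophotometry, measured as kinetic solubility, at pH 8, tested at 500 uM (on this read-out lower numbers stand for lower solubility and higher numbers for higher solubility), giving 48 ug/mL. Compound 2 `Cn1ccc2ccc(-c3cc(Nc4ccccc4S(=O)(=O)N4CCOCC4)cc4nccnc34)cc21` gives 5 ug/mL, and compound 1 `CNS(=O)(=O)c1ccccc1Nc1cc(-c2ccc3ccn(C)c3c2)c2nccnc2c1` gives 2 ug/mL; both stand beyond the scatter below compound 3. Among the measured compounds shown here, the one measured step, a 2.5-fold higher number from compound 1 to compound 2 (0.40 log units; beyond the scatter), concerns a change on a sulfonyl sulfur and is modest in size.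

Compound 4 `CN1CCC(N(C)C(=O)c2ccncc2Nc2cc(-c3ccc4ccn(C)c4c3)c3nccnc3c2)C1` differs from compound 3 in one place: methyl(1-methylpyrrolidin-3-yl)amino in place of (1-methyl-2-oxopiperidin-4-yl)amino on a carbonyl carbon. For the measured compounds named here, no measured step touches the carbonyl carbon or the amines attached to it, so the pair of sulfonyl compounds offers no guide of the same kind, and it only shows that single changes have moved this assay modestly. On that basis compound 4 is expected to stay close to compound 3, with the step of a 1.3-fold higher number from compound 3 to compound 4 (0.10 log units; within the scatter) estimated to lie within the scatter or a little above it. The estimate for compound 4 is 60 ug/mL, with a range from 15 ug/mL to 150 ug/mL.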

Compound 4, solubility: 245 ug/mL
Compound 4: the middle estimate sits 4.1-fold (0.61 log units) below what was measured; the measured number lies above the stated range.
By their numbers in this assay, from the lowest: compound 1; then compound 2; then compound 3; then compound 4.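

Among the compounds shown here, the carbonyl carbon is a place where a single change moves the read-out in this assay, with a 5.1-fold higher number from compound 3 to compound 4 (0.71 log units; beyond the scatter), and this is the first measured step at that position. The change replaces (1-methyl-2-oxopiperidin-4-yl)amino, which has a six-membered ring and a hydrogen-bond donor, with methyl(1-methylpyrrolidin-3-yl)amino, which has a five-membered ring and no hydrogen-bond donor, so ring size and donor count differ together within one step. Nothing measured here explains the rise.

The compounds shown do not separate the effect of the added methyl on the amine from that of the ring change. As far as these compounds go, how a 1-methylpiperidin-4-yl amine or an open-chain dimethylaminoethyl amine would read on the same carbonyl carbon also remains open.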